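The source may hold more compounds than are shown below. What is called first, only, known or untested is meant among the compounds shown, and "the series" means these compounds.

Measured so far in an ADME assay on Vero cells (Chlorocebus sabaeus) for cytotoxicity, read by MTT assay; a higher number here means a weaker inhibitor, a lower number a stronger inhibitor:
- compound 1 `CN(Cc1ccc(F)cc1)c1cc(C(=O)Nc2ccccc2)ncn1` gives 297000 nM
- compound 2 `COc1ccc(NC(=O)c2cc(N(C)Cc3cccc(F)c3)ncn2)cc1` gives 272000 nM

Compound 2 stands within the scatter of compound 1, so these two numbers show no order. Compound 3 `COc1ccc(NC(=O)c2cc(N(C)Cc3ccc(F)cc3)ncn2)cc1` is not yet measured and differs from compound 2 by 4-fluorophenyl in place of 3-fluorophenyl on a saturated chain carbon bound to a nitrogen on an aromatic ring with the rest unchanged. For the measured compounds named here, no step between measured compounds is available to size this change. Compound 1 also carries a 4-fluorophenyl and gives 297000 nM within the scatter of compound 2, so no step beyond the scatter is expected in this assay here. The estimated 1.0-fold higher number from compound 2 to compound 3 (0.01 log units; within the scatter) stays within that scatter. For compound 3 the expected value is 280000 nM with an estimated range from 150000 nM to 500000 nM in this read-out.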

Compound 3, half-maximal inhibitory concentration: 60500 nM
Compound 3: the middle estimate sits 4.6-fold (0.67 log units) above what was measured, and the stated range ends above it.
By their numbers in this assay, from the lowest: compound 3; then compounds 2 and 1 (each within the scatter of the next).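

In this assay this place is not silent: 4-fluorophenyl in place of 3-fluorophenyl on a saturated chain carbon bound to a nitrogen on an aromatic ring gives a 4.5-fold lower number from compound 2 to compound 3 (0.65 log units; beyond the scatter) with the same atoms throughout. With 4-fluorophenyl held, methoxy in place of hydrogen on an aromatic carbon gives a 4.9-fold lower number from compound 1 to compound 3 (0.69 log units; beyond the scatter) and so also registers in this series. Nothing at hand accounts for either step.

From the compounds shown here alone, whether the methoxy step holds with 3-fluorophenyl remains open. So does the effect of unsubstituted phenyl or 4-chlorophenyl at this place, or of ethoxy in place of methoxy.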